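A few compounds are considered here, and "the series" means these few. Any claim that something is new, unique, unknown or untested is made for them only; others in the source may bear on it.

Measured compounds:
- Compound 1 `C/C(=N\N=C1/SCC(=O)N1Cc1cccc(F)c1)c1cccs1`: > 5000000 nM (a limit)
- Compound 2 `C/C(=N\N=C1/SCC(=O)N1Cc1cccc(Cl)c1)c1cccs1`: > 5000000 nM (a limit)
- Compound 3 `CC(C)=N/N=C1\SCC(=O)N1Cc1ccc(N)cc1`: > 5000000 nM (a limit)

In a physicochemical assay, with a stated time of 30 min (a higher number here means a weaker inhibitor, a lower number a stronger inhibitor), compound 2 gives > 5000000 nM, which is a limit and not a number. It therefore stands with the other compounds at the limit of > 5000000 nM in this assay, at which 3 of the 3 values shown sit.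

Compound 4 `C/C(=N\N=C1/SCC(=O)N1Cc1cccc(Cl)c1)c1ccccn1`, not yet measured, carries pyridin-2-yl in place of thiophen-2-yl on a carbon with a double bond to nitrogen.

Within the data shown here, the one measured step, a step that the two limits leave unreadable from compound 1 to compound 2, concerns chloro in place of fluoro on an aromatic carbon, a different change, and gives no size to carry over. No step beyond the scatter is therefore expected in this assay, in either direction.

The expected step is a number no higher from compound 2 to compound 4 (the limit leaves the size open).

For compound 4 the estimated value is 5000000 nM, with an expected range of 1000000 nM to 20000000 nM, and it may well be reported only as a limit.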

Compound 4, half-maximal inhibitory concentration: > 5000000 nM
Compound 4: no number, only a limit; the forecaster's own chance of this, stated with the estimate: 85%; the middle value lies on the limit itself.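

Compound 2 and compound 4 both give only a limit, so no step can be read for pyridin-2-yl in place of thiophen-2-yl: the limit of > 5000000 nM in this assay, at which 4 of the 4 values shown sit.

In this assay the compounds shown leave open which change, if any, would give a measured number instead of a limit.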